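This account rests on a few compounds, and the source may have more. Where it says the series, first, only, none or still open, it means among the compounds named here.

Compound 1 `Cc1ccc(-n2cc(COc3cccc4cnc(Nc5cccc(Cl)c5)nc34)nn2)c([N+](=O)[O-])c1`: 21000 nM
Compound 2 `COc1cccc(-n2cc(COc3cccc4cnc(Nc5cccc(Cl)c5)nc34)nn2)c1`: 18000 nM

Among the compounds with values here, in an ADME assay on cells (Fibroblast, Homo sapiens) for cytotoxicity, read by cell counting, with a stated time of 48 h (a higher number here means a weaker inhibitor, a lower number a stronger inhibitor), the two measured compounds cannot be told apart, so compound 2 stands level with the only other number: a 1.2-fold lower number from compound 1 to compound 2 (0.07 log units; within the scatter). Compound 3 `Clc1cccc(Nc2ncc3cccc(OCc4cn(-c5cc(Cl)cc(Cl)c5)nn4)c3n2)c1` carries 3,5-dichlorophenyl in place of 3-methoxyphenyl on an aromatic nitrogen. Within the data shown here, the only measured swap on that nitrogen, a 1.2-fold lower number from compound 1 to compound 2 (0.07 log units; within the scatter), is small, so no change beyond the scatter is expected in this assay. The expected step is a 1.1-fold lower number from compound 2 to compound 3 (0.02 log units; within the scatter). For compound 3 the estimate is 17000 nM, with an expected range of 7000 nM to 40000 nM.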

Compound 3, half-maximal inhibitory concentration: 8000 nM
Estimate against measurement, compound 3: 2.1-fold (0.33 log units) above; the range from low to high includes it.
By their numbers in this assay, from the lowest: compound 3; then compounds 2 and 1 (each within the scatter of the next).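

The group on this aromatic nitrogen can shift the number in this assay after all, since 3,5-dichlorophenyl gives a 2.3-fold lower number from compound 2 to compound 3 (0.35 log units; beyond the scatter) and also a 2.6-fold lower number from compound 1 to compound 3 (0.42 log units; beyond the scatter). Both steps are modest, and 3-methoxyphenyl and 3,5-dichlorophenyl have the same count of heavy atoms, so that count does not separate them. Nothing available explains the shift. On these data alone, it remains open whether a single chlorine on the phenyl ring would give the same step, and how an amine or a carboxylic acid there would read.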